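The compounds below may be only part of what the source reports. "The series", "measured", "known", "first", "only" and "open" are said of these compounds alone.

The measured compounds:
compound 1 `CS(=O)(=O)c1ccc(Nc2ncc(F)c(Nc3nc4ccccc4s3)n2)cc1`, compound 2 `Cc1ccc2nc(Nc3nc(Nc4ccc(S(N)(=O)=O)cc4)ncc3F)sc2c1`, compound 3 `NS(=O)(=O)c1ccc(Nc2ncc(F)c(Nc3nc4ccccc4s3)n2)cc1`.

In a functional assay on HeLa cells (Homo sapiens) for antiproliferative activity, read by MTT assay, with a stated time of 48 h (on this read-out higher numbers stand for weaker inhibition and lower numbers for stronger inhibition), compound 1 gives 3170 nM. In this assay compound 2 gives 1890 nM. In this assay compound 3 gives 4520 nM.

Compound 2 thus has the lowest of the three numbers. Its nearest neighbour is compound 1, whose number lies within the scatter of it, so these two cannot be put in order. Compound 3 stands further off, as a 2.4-fold higher number from compound 2 to compound 3 (0.38 log units; beyond the scatter) shows, a step made by hydrogen in place of methyl on an aromatic carbon.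

Compound 4 `Cc1ccc2nc(Nc3nc(Nc4ccc(S(C)(=O)=O)cc4)ncc3F)sc2c1` differs from compound 2 in one place: methyl in place of amino on a sulfonyl sulfur. The same exchange, taken in the opposite direction, has been measured once among these compounds: a 1.4-fold higher number from compound 1 to compound 3 (0.15 log units; within the scatter). That step stayed within the scatter, so exchanging the two groups on the sulfonyl sulfur left the number effectively unchanged there. On that basis no step beyond the scatter is expected in this assay from compound 2 to compound 4; if anything, a slightly lower number is expected, mirroring the small rise seen between compound 1 and compound 3.

Compound 4 is therefore estimated at 1400 nM, with a range from 700 nM to 2800 nM, which amounts to an expected step of a 1.4-fold lower number from compound 2 to compound 4 (0.13 log units; within the scatter).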

Compound 4, half-maximal inhibitory concentration: 17200 nM
For compound 4 the middle estimate is 12-fold (1.09 log units) below the measured one; the whole stated range lies below it.
By their numbers in this assay, from the lowest: compounds 2, 1 and 3 (each within the scatter of the next, the first and the last beyond it); then compound 4.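

In this assay, the exchange of amino and methyl on a sulfonyl sulfur turns out to depend on the rest of the molecule. With a methyl group on the aromatic carbon of the core, this exchange gives a 9.1-fold higher number from compound 2 to compound 4 (0.96 log units; beyond the scatter), whereas on the core of compound 1 it stayed within the scatter, so the two cores do not respond alike: the same change on two cores in this assay, a 1.4-fold higher number (0.15 log units; within the scatter) from compound 1 to compound 3 and a 9.1-fold lower number (0.96 log units; beyond the scatter) from compound 4 to compound 2, 13-fold (1.11 log units) apart, beyond the scatter of two such steps. The methyl group on the aromatic carbon likewise depends on what the sulfonyl sulfur carries: with the methylsulfonyl group it goes with a 5.4-fold higher number from compound 1 to compound 4 (0.73 log units; beyond the scatter), while with the sulfamoyl group the step runs the opposite way: the same change on two cores in this assay, a 2.4-fold higher number (0.38 log units; beyond the scatter) from compound 2 to compound 3 and a 5.4-fold lower number (0.73 log units; beyond the scatter) from compound 4 to compound 1, 13-fold (1.11 log units) apart, beyond the scatter of two such steps.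

From the compounds shown here alone, it remains open whether a different group on that aromatic carbon, such as chloro or methoxy, would show the same dependence, and whether a group such as ethyl or dimethylamino on the sulfonyl sulfur would behave like methyl or like amino. This dependence rests on a single set of four compounds in one assay, and these numbers alone do not explain it.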